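A few compounds are considered here, and "the series" means these few. Any claim that something is new, unique, unknown or untested is made for them only; others in the source may bear on it.

Three compounds have been measured in a functional assay on A-375 cells (Homo sapiens) for antiproliferative activity, read by MTT assay, with a stated time of 24 h, tested at 11.11 ug/mL; a higher number here means a stronger effect of the compound at the concentration tested, a lower number a weaker effect:

compound 1, `CCc1ccc2nc(C(=O)Nc3c(F)cc(-c4cccc(F)c4)cc3F)c(C)c(O)c2c1`, which gives 26.4%;
compound 2, `Cc1c(C(=O)Nc2c(F)cc(-c3cccc(F)c3)cc2F)nc2ccc(F)cc2c1O`, which gives 16.2%;
compound 3, `Cc1c(C(=O)Nc2c(F)cc(-c3cccc(F)c3)cc2F)nc2ccc(C(F)(F)F)cc2c1O`, which gives 46.3%.

Compound 2 has the lowest of the three numbers. Its nearest neighbour is compound 1, from which it is reached by fluoro in place of ethyl on an aromatic carbon, a step of a number 10.2 percentage points lower from compound 1 to compound 2 (beyond the scatter). Its furthest is compound 3, reached by trifluoromethyl in place of fluoro on an aromatic carbon, a step of a number 30.1 percentage points higher from compound 2 to compound 3 (beyond the scatter). Exchanging the ethyl for a trifluoromethyl group instead gives a number 19.9 percentage points higher from compound 1 to compound 3 (beyond the scatter). All three steps vary one and the same substituent on the shared core.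

Compound 4, `Cc1c(C(=O)Nc2c(F)cc(-c3cccc(F)c3)cc2F)nc2ccc(F)cc2c1C(=O)O`, differs from compound 2 at another place: carboxy in place of hydroxy on an aromatic carbon. Among the measured compounds shown here, none of the measured steps touches the hydroxy group, so none of them bears on this change; they speak only to the group that is fluoro in compound 2. The measured data therefore give no basis for expecting a step in either direction in this assay, and any estimate must be wide. Compound 4 is expected to give about 16% in this assay, within a range from 2% to 40%. That estimate means an expected step of a number 0.2 percentage points lower from compound 2 to compound 4 (within the scatter), within the usual scatter.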

Compound 4, a percentage reported as inhibition, at one concentration (the size of the read-out at that concentration, not a potency): 36.3%
Compound 4: the middle estimate sits 20.3 percentage points below what was measured; the measured number falls inside the stated range.
By their numbers in this assay, from the lowest: compound 2; then compounds 1, 4 and 3 (each within the scatter of the next, the first and the last beyond it).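

In this assay, the place opposite the ring nitrogen, ortho to a methyl group, proves able to move the number: a number 20.1 percentage points higher from compound 2 to compound 4 (beyond the scatter), a modest step. The hydroxy group is therefore not needed for the effect read here, at least with fluoro as the other substituent, since carboxy in its place gives a higher number, with the same count of hydrogen-bond donors and acceptors and two more heavy atoms. Among the compounds shown here, until now every step had varied only the group that is ethyl, fluoro or trifluoromethyl, so this is the first sign that a second place on the shared core matters, although nothing available bears on why the exchange has this effect.

The compounds shown leave open whether carboxy would bring a similar step with ethyl or trifluoromethyl as the other substituent, since compound 4 is the only one with carboxy and no such pair stands here. They also leave open how other groups would behave at this place, such as a methyl ester, a primary amide, an amine or a simple hydrogen, and whether the step would hold as a difference in potency rather than at one concentration.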